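A few compounds are considered here, and "the series" means these few. Any claim that something is new, unique, unknown or untested is made for them only; others in the source may bear on it.

Compound 3 `COc1ccc(N2C[C@@H](C)N[C@@H](C)C2)cc1NS(=O)(=O)c1ccc(-c2ccccn2)s1` carries the lowest of the three numbers measured in a functional assay for agonist activity at growth hormone secretagogue receptor type 1 (Homo sapiens), read by FLIPR; on this read-out higher numbers stand for an effect only at larger amounts of compound and lower numbers for an effect already at smaller amounts: compound 3 gives 10 nM. Compound 1 `COc1ccc(NS(=O)(=O)c2ccc(-c3ccccn3)s2)cc1N1C[C@@H](C)N[C@@H](C)C1` gives 15.9 nM, a gap from compound 3 that stays within the scatter, while compound 2 `C[C@@H]1CN(c2cccc(NS(=O)(=O)c3ccc(-c4ccccn4)s3)c2)C[C@H](C)N1` gives 39.8 nM, a gap from compound 3 that goes beyond it. Compound 4 `CCOc1ccc(N2C[C@@H](C)N[C@@H](C)C2)cc1NS(=O)(=O)c1ccc(-c2ccccn2)s1` differs from compound 3 by methyl in place of hydrogen on a saturated chain carbon bound to an oxygen on an aromatic ring, so methoxy becomes ethoxy. The measured steps concern only whether a methoxy is present at all: a 2.5-fold higher number from compound 1 to compound 2 (0.40 log units; beyond the scatter) and a 4.0-fold lower number from compound 2 to compound 3 (0.60 log units; beyond the scatter). Among the compounds with values here, no measured step lengthens a methoxy into an ethoxy, so a change no larger than the scatter is expected, written as a 1.2-fold higher number from compound 3 to compound 4 (0.08 log units; within the scatter). Compound 4 is therefore estimated at 12 nM, within a range from 4 nM to 35 nM.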

Compound 4, half-maximal effective concentration: 39.8 nM
Beside the measured number, compound 4's estimate is 3.3-fold (0.52 log units) below it, outside the stated range (above it).
By their numbers in this assay, from the lowest: compounds 3 and 1 (each within the scatter of the next); then compounds 2 and 4 (each within the scatter of the next).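

Earlier steps showed only that having a methoxy at this place matters; this one shows that its length matters too, since methoxy to ethoxy gives a 4.0-fold higher number from compound 3 to compound 4 (0.60 log units; beyond the scatter) in this assay. A single added methyl removes the whole gain seen with methoxy, for ethoxy in place of hydrogen gives no change at the digits printed from compound 2 to compound 4 (within the scatter). No available evidence explains why this one methyl has such an effect. From the compounds shown here alone, it remains open whether a longer chain such as propoxy would follow the same trend, and how a fluorine at this place would compare.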